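The source may hold more compounds than are shown below. What is called first, only, known or untested is meant among the compounds shown, and "the series" means these compounds.

Measured in an ADME assay on MT4 cells (Homo sapiens) for cytotoxicity; a higher number here means that more compound is tolerated, a lower number that less compound is tolerated:
- compound 1 `Cc1ccccc1NC(=O)COc1ccccc1Cn1ccc(=O)n(C)c1=O`: 152000 nM
- compound 2 `C=CCn1c(=O)ccn(Cc2ccccc2OCC(=O)Nc2ccccc2Cl)c1=O`: 30600 nM
- compound 3 `Cc1cc(C)cc(Cn2c(=O)ccn(CC(=O)Nc3ccccc3C)c2=O)c1`: 292000 nM

Compound 3, at 292000 nM, cannot be told apart from compound 1, at 152000 nM, since the two lie within the usual scatter. Compound 2, at 30600 nM, lies clearly lower than both.

Compound 4 `Cc1cc(C)cc(Cn2c(=O)ccn(CC(=O)NCc3ccccc3)c2=O)c1` carries benzyl in place of 2-methylphenyl on an amide-type nitrogen. For the measured compounds named here, no two measured compounds differ in one place only, so nothing here tests this change directly. A small downward move or none beyond the scatter is expected, with compound 2 as a reminder that lower numbers occur. The estimated step is a 1.5-fold lower number from compound 3 to compound 4 (0.16 log units; within the scatter). For compound 4 the expected value is 200000 nM, with a range of 70000 nM to 400000 nM.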

Compound 4, half-maximal cytotoxic concentration: 191000 nM
For compound 4 the middle estimate is 1.0-fold (0.02 log units) above the measured one, and the stated range covers the measured number.
By their numbers in this assay, from the lowest: compound 2; then compounds 1, 4 and 3 (each within the scatter of the next).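

The first direct test of this position comes from benzyl in place of 2-methylphenyl on an amide-type nitrogen, which in this assay gives a 1.5-fold lower number from compound 3 to compound 4 (0.18 log units; within the scatter). The two compounds have the same atoms joined differently, and they cannot be told apart here, so this swap leaves the tolerated concentration unresolved from compound 3. Nothing available explains this result.

From the compounds shown here alone, whether an amine or a carboxylic acid on the benzyl ring would also stay within the scatter remains open. So does whether the same swap would read alike on the core of compound 1 or compound 2.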